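Cytotoxicity notes on a four-compound amide series

The source may hold more compounds than are shown below. What is called first, only, known or untested is meant among the compounds shown, and "the series" means these compounds.

Measured compounds:
compound 1, `CCCNc1ccc(NC(=O)c2cc(Cl)ccc2O)c(Cl)c1`, 69700 nM
compound 2, `O=C(Nc1ccc(N2CCCC2)cc1Cl)c1cc(Cl)ccc1O`, "not determined" (no result reported)
compound 3, `CC(=O)Nc1ccc(NC(=O)c2cc(Cl)ccc2O)c(Cl)c1`, "not determined" (no result reported)

Only compound 1 carries a number in an ADME assay on A549 cells (Homo sapiens) for cytotoxicity, read by LDH release, with a stated time of 15 h; on this read-out higher numbers stand for lower toxicity in this test and lower numbers for higher toxicity in this test; in this assay compound 1 gives 69700 nM. For compound 2 this assay reports "not determined" (no result reported), and for compound 3 it likewise reports "not determined" (no result reported). Among the compounds with values here, with a single measured value, compound 1 stands alone as the reference point for the series, and no step between measured compounds can be given.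

Compound 4, `O=C(Nc1ccc(NCc2ccco2)cc1Cl)c1cc(Cl)ccc1O`, is the next member to be run in this assay. Its difference from compound 1 is a single substitution: furan-2-yl in place of ethyl on a saturated chain carbon bound to a nitrogen on an aromatic ring. The shared core, the amide link and the chloro substitution on both rings are untouched; the change sits entirely in the substituent on the nitrogen on the aromatic ring.

Within the data shown here, with no measured step to lean on, the expectation for this assay is a small move, if any, toward higher toxicity, and most likely a step that stays within the usual scatter. Compound 4 is estimated at 50000 nM, with a range of 20000 nM to 130000 nM. That estimate means a step of a 1.4-fold lower number from compound 1 to compound 4 (0.14 log units; within the scatter), expected to be modest and not clearly beyond repeat-measurement noise.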

Compound 4, half-maximal cytotoxic concentration: 76300 nM
Estimate against measurement, compound 4: 1.5-fold (0.18 log units) below; the measured number falls inside the stated range.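

Working notes after compound 4. The exchange of ethyl for furan-2-yl on a saturated chain carbon bound to a nitrogen on an aromatic ring comes out in this assay as a 1.1-fold higher number from compound 1 to compound 4 (0.04 log units; within the scatter) and stays within the usual scatter, so the two compounds read alike. Within the data shown here, this is the first readable pair, and it shows that a five-membered aromatic ring with 1 hetero atom and 1 hydrogen-bond acceptor can enter at this position with no change in this read-out that can be told from repeat-measurement noise. No supporting measurement bears on why the two compounds read alike.

Steps to compound 2 and compound 3 cannot be read, as neither carries a number, so this single pair remains the only comparison and supports no trend across the series. From the compounds shown here alone, whether the same flat result would hold for a phenyl ring, a longer chain such as butyl, or a chain ending in a carboxylic acid or an amine at this position remains open.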